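An Amino Group Added to a Labile Core

The source may hold more compounds than are shown below. What is called first, only, known or untested is meant among the compounds shown, and "the series" means these compounds.

Of the compounds shown here, three have been measured in an ADME assay on microsomes from liver (Rattus norvegicus), read by LC-MS, using NADPH, with a stated time of 30 min, tested at 1 uM; a higher number here means that more of the compound is left, a lower number that less of the compound is left. Compound 1 `C[C@H](Nc1nc(N)nc(N)c1C#N)c1cc2ccc(F)cn2c(=O)c1-c1ccccc1` gives 88%, and compound 2 `C[C@H](Nc1nc(N)ncc1C#N)c1cc2ccc(F)cn2c(=O)c1-c1ccccc1` gives 74%. The two differ by amino in place of hydrogen on an aromatic carbon, and this change produced a number 14 percentage points higher from compound 2 to compound 1 (beyond the scatter). Compound 3 `C[C@H](Nc1ncnc(N)c1C#N)c1c(C2CC2)c(=O)n2cc(F)ccc2c1-c1ccc(F)cc1` gives 1%, the lowest of the three; how its core differs from that of compound 2 is not broken down here.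

Compound 4 `C[C@H](Nc1nc(N)nc(N)c1C#N)c1c(C2CC2)c(=O)n2cc(F)ccc2c1-c1ccc(F)cc1` has not yet been measured in this assay. It differs from compound 3 by amino in place of hydrogen on an aromatic carbon. Going by the values given here, this is the same kind of change as the one from compound 2 to compound 1, not the same: there the amino group enters next to the ring nitrogen, ortho to the cyano group and opposite the ring nitrogen, whereas here it enters between two ring nitrogen atoms and para to the cyano group.

The step expected in this assay is a number 7 percentage points higher from compound 3 to compound 4 (within the scatter); this rests on the earlier change giving a number 14 percentage points higher from compound 2 to compound 1 (beyond the scatter), while compound 3 starts from a far lower value. Compound 4 is therefore estimated to give about 8%, between 1% and 30%.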

Compound 4, percent of the compound remaining: 35%
The estimate for compound 4 lay 27 percentage points below the measured number, and the stated range ends below it.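

In this assay, amino in place of hydrogen on an aromatic carbon gave a number 34 percentage points higher from compound 3 to compound 4 (beyond the scatter) and so raised the number on both cores shown, but the size of the step did not carry over from one core to the other: the same change on two cores in this assay, a number 14 percentage points higher (beyond the scatter) from compound 2 to compound 1 and a number 34 percentage points higher (beyond the scatter) from compound 3 to compound 4, 20 percentage points apart, beyond the scatter of two such steps. The direction held across these two pairs, and the larger step came on the core of compound 3, whose number started far lower. The two steps do not show whether the gap between them belongs to the core or to the place where the amino group enters, since that place, here between two ring nitrogen atoms and para to a cyano group, is not the same in both pairs, and two pairs make no rule for other cores in the series.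

The compounds shown leave open whether a methylamino group or a methyl group in this place would give a step like that of the amino group. They also leave open how a hydroxyl group there would compare on either core.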